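Working notes: from compound 3 to compound 4

The source may report more compounds than this note shows. Statements on the series, on what has been measured and on what is new or still open speak of the compounds shown alone.

In a functional assay on MCF7 cells (Homo sapiens) for cytotoxicity, read by MTT assay, with a stated time of 72 h (a higher number here means a weaker inhibitor, a lower number a stronger inhibitor), compound 3 (`COc1cc2ncnc(Nc3ccc(F)c(Cl)c3)c2cc1NC(=O)N/N=C/c1ccc(C#N)cc1`) reads "not determined" (no result reported) and so offers no single number as a starting point. Compound 1 (`N#Cc1ccc(/C=N/NC(=O)Nc2cc3c(Nc4ccc(F)c(Cl)c4)ncnc3cc2O[C@H]2CCOC2)cc1`) reads "not determined" (no result reported) in the same way. For the measured compounds named here, compound 2 (`CC(C)(C)c1cc(/C=N/NC(=O)Nc2cc3c(Nc4ccc(F)c(Cl)c4)ncnc3cc2O[C@H]2CCOC2)cc(C(C)(C)C)c1O`) gives 14500 nM and holds the only number so far.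

Compound 4 (`COc1cc2ncnc(Nc3ccc(F)c(Cl)c3)c2cc1NC(=O)N/N=C/c1ccc(OC)c(OC)c1OC`) carries 2,3,4-trimethoxyphenyl in place of 4-cyanophenyl on a carbon with a double bond to nitrogen, counted as 2,3,4-trimethoxyphenyl in place of 4-cyanophenyl on a carbon with a double bond to nitrogen against compound 3. Going by the values given here, no measured step sizes this change, and compound 3 has no value to step from. Among the compounds with values here, the expectation in this assay is therefore no shift beyond the usual scatter, in either direction, and the estimate leans on compound 2 at 14500 nM as the sole number available. The expected value for compound 4 is about 12000 nM within an estimated range from 3000 nM to 45000 nM until the measurement is in.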

Compound 4, half-maximal inhibitory concentration: "not active" (no number reported)
For compound 4 the study gives words and no number; no gap can be computed for the estimate.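

In this assay, for the compounds shown here, compound 3 reads "not determined" and compound 4 reads "not active", so no step between them can be read. The compounds shown leave open how 2,3,4-trimethoxyphenyl compares with 4-cyanophenyl on potency. No evidence bears on this result.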